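The source may hold more compounds than are shown below. What is called first, only, known or untested is meant among the compounds shown, and "the series" means these compounds.

Compound 1 `O=S(=O)(c1ccc(F)cc1)c1cnc2c(F)cccc2c1-c1cccc(F)c1` gives 1.56 mL/min in an ADME assay on microsomes from liver (Homo sapiens) for metabolic stability, tested at 2.5 uM; a higher number here means faster removal of the compound, a lower number slower removal.
Compound 2 `O=S(=O)(c1cc(Cl)cc(Cl)c1)c1cnc2c(F)cccc2c1-c1cccc(F)c1` gives 1.08 mL/min in this assay.

Compound 2 has the lowest of the two numbers in this assay; its nearest neighbour is compound 1, and the step of a 1.4-fold lower number from compound 1 to compound 2 (0.16 log units; within the scatter) lies within the scatter. Compound 3 `Cc1ccc(S(=O)(=O)c2cnc3c(F)cccc3c2-c2cccc(F)c2)cc1F` differs from compound 2 by 3-fluoro-4-methylphenyl in place of 3,5-dichlorophenyl on a sulfonyl sulfur. Among the measured compounds shown here, the only step bearing on this change, a 1.4-fold lower number from compound 1 to compound 2 (0.16 log units; within the scatter), shows that swapping one phenyl on the sulfonyl sulfur for another moved the number little. No step beyond the scatter is therefore expected for compound 3 in this assay, with a 1.3-fold higher number from compound 2 to compound 3 (0.11 log units; within the scatter) as the expected step. Compound 3 is estimated at 1.4 mL/min, within 0.7 mL/min to 2.8 mL/min.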

Compound 3, intrinsic clearance in a liver preparation (reported as CLH), per the amount of preparation that the assay uses: 3.92 mL/min
Beside the measured number, compound 3's estimate is 2.8-fold (0.45 log units) below it; the measured number lies above the stated range.
By their numbers in this assay, from the lowest: compounds 2 and 1 (each within the scatter of the next); then compound 3.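

Swapping one phenyl for another on the sulfonyl sulfur can move the number in this assay after all: 3-fluoro-4-methylphenyl in place of 3,5-dichlorophenyl gives a 3.6-fold higher number from compound 2 to compound 3 (0.56 log units; beyond the scatter), and in place of 4-fluorophenyl it gives a 2.5-fold higher number from compound 1 to compound 3 (0.40 log units; beyond the scatter). Compound 3 therefore stands apart from compound 1 and compound 2, which remain within the scatter of each other. Nothing measured here accounts for this difference.

The compounds shown do not separate the methyl from the fluorine of 3-fluoro-4-methylphenyl. On these data alone, how an amine or a carboxylic acid on this phenyl would stand in this assay also remains open.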